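Ring size on the amide nitrogen: compound 1 to compound 4

A few compounds are considered here, and "the series" means these few. Any claim that something is new, unique, unknown or untested is made for them only; others in the source may bear on it.

Measured so far in a functional assay on MIA PaCa-2 cells (Homo sapiens) for inhibition; a higher number here means a weaker inhibitor, a lower number a stronger inhibitor:
- compound 1 `CCC(C)C(NC(=O)n1nnc2ccccc21)C(=O)NC1CCCCC1`: compound 1 gives 40200 nM
- compound 2 `CC(C)C(NC(=O)NO)C(=O)NC1CCCCC1`: compound 2 gives > 100000 nM, which is a limit of the assay and not a number
- compound 3 `CCC(C)C(NC(=O)NO)C(=O)NC(c1ccccc1)c1ccccc1`: compound 3 gives 63800 nM

Compound 1 has the lowest of the two numbers, but compound 3 sits within the scatter of it, so no order between compound 1 and compound 3 is claimed. Compound 2 stands at the limit (the limit of > 100000 nM in this assay, at which 1 of the 3 values shown sits).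

Compound 4 `CCC(C)C(NC(=O)n1nnc2ccccc21)C(=O)NC1CCCC1` has not been measured in this assay. Against compound 1 it carries cyclopentyl in place of cyclohexyl on an amide-type nitrogen. For the measured compounds named here, no measured pair shows this change, and the two rings count the same donors and acceptors. The step of a 1.2-fold higher number from compound 1 to compound 4 (0.09 log units; within the scatter) is expected to stay within the scatter, with no direction claimed beyond it. Compound 4 is estimated at 50000 nM, in the range 18000 nM to 140000 nM.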

Compound 4, half-maximal inhibitory concentration: >= 100000 nM
Compound 4: a limit, no number (the forecaster's own chance of this, stated with the estimate: 25%); middle value at least 2.0-fold (0.30 log units) away from the limit.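

In this assay, replacing cyclohexyl with cyclopentyl on the amide-type nitrogen gives an at least 2.4-fold higher number from compound 1 to compound 4 (0.39 log units; beyond the scatter). This single-place pair shows that the position responds to ring size, although neither ring carries hydrogen-bond donors or acceptors. The value for compound 4 is a limit and not a number: the limit of >= 100000 nM in this assay, at which 1 of the 4 values shown sits.

As far as these compounds go, the true size of the step therefore remains open. Also open, from the compounds shown here alone, is whether cycloheptyl or phenyl at this position would give a lower number than compound 1, or whether cyclohexyl is already the better fit.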